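This account rests on a few compounds, and the source may have more. Where it says the series, first, only, none or still open, it means among the compounds named here.

Compound 3, whose structure is `O=C(C1CC1)N1CCN(Cc2nc3ccccc3n2Cc2ccccc2)CC1`, was tested in an assay on isolated protein for inhibition of aldehyde dehydrogenase 1A1 (Homo sapiens), read by spectrophotometry, tested at 10 uM (a higher number here means more inhibition at the concentration tested (going by the name of the read-out), a lower number less inhibition), and gave 23.9%. Of the three numbers shown it is the highest, although the gaps to the other two fall within the scatter: compound 1, with the structure `Cc1cccc(Cn2c(CN3CCN(C(=O)c4ccc(C(F)(F)F)cc4)CC3)nc3ccccc32)c1`, gave 22.9% in this assay, and compound 2, with the structure `Cc1cccc(Cn2c(CN3CCN(C(=O)c4ccc(C#N)cc4)CC3)nc3ccccc32)c1`, gave 20.8%. The three compounds therefore cannot be told apart on these numbers.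

Among the compounds with values here, the only pair that differs in one place is compound 1 and compound 2, where a cyano stands in place of a trifluoromethyl on an aromatic carbon, and that step was a number 2.1 percentage points lower from compound 1 to compound 2 (within the scatter), within the scatter.

Compound 4, with the structure `Cc1ccccc1Cn1c(CN2CCN(C(=O)C3CC3)CC2)nc2ccccc21`, has not yet been measured. It differs from compound 3 in one place: methyl in place of hydrogen on an aromatic carbon. No measured step touches this part of the molecule, so no direct comparison exists; the one step that is shown changed a different ring and stayed within the scatter. With nothing pointing either way, the expectation is a step of a number 0.1 percentage points higher from compound 3 to compound 4 (within the scatter), that is, no change beyond the scatter. Compound 4 is therefore estimated to give 24% in this assay, with a range from 12% to 38%.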

Compound 4, a percentage reported as inhibition, at one concentration (the size of the read-out at that concentration, not a potency): 29.1%
Estimate against measurement, compound 4: 5.1 percentage points below; measured number inside the range.
By their numbers in this assay, from the lowest: compounds 2, 1, 3 and 4 (each within the scatter of the next).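

In this assay, within the data shown here, the change from benzyl to 2-methylbenzyl gives the first direct reading on this ring, and the step was a number 5.2 percentage points higher from compound 3 to compound 4 (within the scatter). A methyl on this aromatic carbon, ortho to a large group, therefore leaves the read-out without a change beyond the scatter, so this one added carbon cannot be said to either help or harm inhibition at the concentration tested. No measurement shown offers an explanation for this result, and a single pair of compounds cannot show whether the same change would behave alike on another scaffold.

On these data alone, what remains open is whether a different group in place of this methyl, such as an ethyl, a methoxy group, an amine or a carboxylic acid, would produce a step beyond the scatter, in either direction. All the compounds shown so far also lie close together, so none of these comparisons yet identifies a change that clearly alters inhibition, and a reading at a single concentration gives no measure of potency for any of them.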